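This account rests on a few compounds, and the source may have more. Where it says the series, first, only, none or still open, it means among the compounds named here.

Measured compounds:
compound 1 `Cc1ccc(S(=O)(=O)c2cnc3cc(F)ccc3c2-c2ccc(F)cc2)cc1C`, 9.25 mL/min
compound 2 `O=S(=O)(c1ccc(F)c(Cl)c1)c1cnc2cc(F)ccc2c1-c1ccc(F)cc1`, 0.69 mL/min
compound 3 `Cc1ccc(S(=O)(=O)c2cnc3cc(F)ccc3c2-c2cccc(Cl)c2)cc1C`, 4.01 mL/min

All three numbers come from an ADME assay on microsomes from liver (Homo sapiens) for metabolic stability, tested at 2.5 uM; on this read-out lower numbers stand for slow clearance and higher numbers for fast clearance. Two single-point changes are covered. From compound 1 to compound 2 the change is 3-chloro-4-fluorophenyl in place of 3,4-dimethylphenyl on a sulfonyl sulfur and it gave a 13-fold lower number from compound 1 to compound 2 (1.13 log units; beyond the scatter). From compound 1 to compound 3 the change is 3-chlorophenyl in place of 4-fluorophenyl on an aromatic carbon and it gave a 2.3-fold lower number from compound 1 to compound 3 (0.36 log units; beyond the scatter). Compound 3 therefore sits between the other two, below compound 1 and above compound 2.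

Compound 4 `O=S(=O)(c1ccc(F)c(Cl)c1)c1cnc2cc(F)ccc2c1-c1cccc(Cl)c1` is not yet measured in this assay. It differs from compound 3 by 3-chloro-4-fluorophenyl in place of 3,4-dimethylphenyl on a sulfonyl sulfur. The same change, at the same place with the same neighbour, takes compound 1 to compound 2, so the step has been seen once before. The cores of the two pairs differ by 3-chlorophenyl in place of 4-fluorophenyl on an aromatic carbon, and that is the only respect in which the pairs are unlike. A single prior step is a thin basis, and nothing shows how the change behaves on the core of compound 3. Even so, the step from compound 3 to compound 4 is expected to be of about the same size as the earlier one, a 10-fold lower number from compound 3 to compound 4 (1.00 log units; beyond the scatter), because the one prior instance gave a 13-fold lower number from compound 1 to compound 2 (1.13 log units; beyond the scatter). On that footing compound 4 is estimated at 0.4 mL/min, with a range from 0.15 mL/min to 1.2 mL/min.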

Compound 4, intrinsic clearance in a liver preparation (reported as CLH), per the amount of preparation that the assay uses: 0.66 mL/min
Compound 4: the middle estimate sits 1.7-fold (0.22 log units) below what was measured; the range from low to high includes it.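

In this assay, 3-chloro-4-fluorophenyl in place of 3,4-dimethylphenyl on a sulfonyl sulfur again gave a step beyond the scatter, a 6.1-fold lower number from compound 3 to compound 4 (0.78 log units; beyond the scatter), and its size cannot be told from that of the earlier instance: the same change on two cores in this assay, a 13-fold lower number (1.13 log units; beyond the scatter) from compound 1 to compound 2 and a 6.1-fold lower number (0.78 log units; beyond the scatter) from compound 3 to compound 4, 2.2-fold (0.34 log units) apart, within the scatter of two such steps. The other change, 3-chlorophenyl in place of 4-fluorophenyl on an aromatic carbon, gave a 1.0-fold lower number from compound 2 to compound 4 (0.02 log units; within the scatter), and this step likewise cannot be told from its earlier counterpart: the same change on two cores in this assay, a 2.3-fold lower number (0.36 log units; beyond the scatter) from compound 1 to compound 3 and a 1.0-fold lower number (0.02 log units; within the scatter) from compound 2 to compound 4, 2.2-fold (0.34 log units) apart, within the scatter of two such steps. The sulfonyl change therefore carried from the core of compound 1 to the core of compound 3, but these two cores differ in one place only, so nothing here shows how it would carry to a more distant core or why the numbers move.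

The compounds shown leave open whether a phenyl bearing chlorine alone or fluorine alone on the sulfonyl sulfur would give the same step. Also open, on these data alone, is how an amine or a carboxylic acid on that ring would read in this assay.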